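Swapping a tert-butyl ester for benzyl on a thiophene-bearing core

The source may hold more compounds than are shown below. What is called first, only, known or untested is meant among the compounds shown, and "the series" means these compounds.

Of the compounds shown here, three with a shared core have so far been tested in an assay on membranes from CHO cells for displacement of a labelled ligand from adenosine receptor A1 (Homo sapiens), read by scintillation counting, with a stated time of 60 min, tested at 1 uM; a lower number here means less inhibition, a higher number more inhibition at the concentration tested (going by the name of the read-out). Compound 1 `CC1=C(C(=O)OCc2ccccc2)C(c2ccco2)NC(=S)N1` gives 32%, and compound 2 `CC1=C(C(=O)OCc2ccccc2)C(c2cccs2)NC(=S)N1` gives 34%. Compound 3 `CC1=C(C(=O)OC(C)(C)C)C(c2ccsc2)NC(=S)N1` gives 16%, the lowest of the three numbers; its gap to compound 1 and to compound 2 lies beyond the usual scatter, whereas the two benzyl esters sit close together.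

Going by the values given here, the only measured step, a number 2 percentage points higher from compound 1 to compound 2 (within the scatter), is within the scatter and concerns a swap of one five-membered heteroaryl for another on the saturated ring carbon. It does not touch the ester.

Compound 4 `CC1=C(C(=O)OCc2ccccc2)C(c2ccsc2)NC(=S)N1` arises from compound 3 by a change at the ester: benzyl in place of tert-butyl on an oxygen next to a carbonyl group. Among the compounds with values here, no measured step covers this exact exchange. What the numbers do show is that compound 1 and compound 2, the two benzyl esters, give higher inhibition than compound 3, the tert-butyl ester, by amounts beyond the scatter. On that basis the ester change is expected to raise inhibition in this assay, with an estimated step of a number 14 percentage points higher from compound 3 to compound 4 (beyond the scatter). Compound 4 is therefore expected to give about 30%, with a likely range from 15% to 45%.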

Compound 4, a percentage reported as inhibition, at one concentration (the size of the read-out at that concentration, not a potency): 3%
Beside the measured number, compound 4's estimate is 27 percentage points above it; measured number outside the range, below it.
By their numbers in this assay, from the lowest: compound 4; then compound 3; then compounds 1 and 2 (each within the scatter of the next).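

In this assay, the ester position now has a step of its own: benzyl in place of tert-butyl on an oxygen next to a carbonyl group gives a number 13 percentage points lower from compound 3 to compound 4 (beyond the scatter), so with thiophen-3-yl on the saturated ring carbon the benzyl ester goes with less inhibition. Going by these compounds alone, the saturated ring carbon also proves sensitive, although the only step known there before, a number 2 percentage points higher from compound 1 to compound 2 (within the scatter), was within the scatter: with the benzyl ester kept, thiophen-3-yl in place of thiophen-2-yl gives a number 31 percentage points lower from compound 2 to compound 4 (beyond the scatter), and thiophen-3-yl in place of furan-2-yl gives a number 29 percentage points lower from compound 1 to compound 4 (beyond the scatter). The point at which the thiophene ring is attached therefore makes a difference in this assay that the exchange of furan-2-yl for thiophen-2-yl did not make.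

Nothing available here explains why these exchanges change the inhibition. From the compounds shown here alone, it remains open whether benzyl in place of tert-butyl would also lower inhibition with thiophen-2-yl or furan-2-yl on the ring carbon, and what a carboxylic acid, an amide or a longer chain at the ester position would do.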